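Swapping a Silyl Ether for an Allyl Ether

A few compounds are considered here, and "the series" means these few. Any claim that something is new, unique, unknown or untested is made for them only; others in the source may bear on it.

Going by the values given here, compound 2 `C[C@@]12CCC[C@]3(COC1=O)C1=C(C=C[C@H]32)C(=O)C=C(O[Si](C)(C)C)C1=O` is one of two compounds measured in an ADME assay on Vero cells (Chlorocebus sabaeus) for cytotoxicity, read by microscopy, with a stated time of 24 h, tested at 5 ug/mL; on this read-out higher numbers stand for a weaker effect at the one concentration tested and lower numbers for a stronger effect; compound 2 gives 99.1%. Compound 1 `CC(=O)OC1=CC(=O)C2=C(C1=O)[C@]13CCC[C@](C)(C(=O)OC1)[C@@H]3C=C2` gives 99.2%. Among the compounds with values here, on these two numbers compound 2 stands lowest, but its only neighbour, compound 1, lies within the scatter, so the two readings cannot be separated. Compound 3 `C=CCOC1=CC(=O)C2=C(C1=O)[C@]13CCC[C@](C)(C(=O)OC1)[C@@H]3C=C2` has not been measured yet. It differs from compound 2 in one place: a group of 3 heavy atoms (3 carbon; no ring) in place of a group of 4 heavy atoms (3 carbon, 1 silicon; no ring), on an oxygen on an unsaturated carbon. Within the data shown here, the single measured step, a number 0.1 percentage points lower from compound 1 to compound 2 (within the scatter), also exchanged the group on an oxygen on an unsaturated carbon and brought no difference beyond the scatter, so the present exchange is expected to behave alike. For compound 3 a step of a number 0.6 percentage points lower from compound 2 to compound 3 (within the scatter) is therefore expected, that is, none beyond the scatter. Compound 3 is estimated at 98.5% in this assay, with a range from 90% to 100%.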

Compound 3, a percentage reported as activity, at one concentration (the size of the read-out at that concentration, not a potency): 99.1%
For compound 3 the middle estimate is 0.6 percentage points below the measured one; the measured number falls inside the stated range.
By their numbers in this assay, from the lowest: compounds 2, 3 and 1 (each within the scatter of the next).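

On the oxygen on an unsaturated carbon, allyl, which brings a double bond outside any ring and no silicon, can replace the silicon-bearing group in this assay, and the step is no change at the digits printed from compound 2 to compound 3 (within the scatter). Set against acetyl, the step is a number 0.1 percentage points lower from compound 1 to compound 3 (within the scatter), so three different groups on this oxygen now give readings that cannot be told apart in this assay at the one concentration tested. No supporting data explain why these groups read alike.

From the compounds shown here alone, whether an amine, a carboxylic acid or a longer carbon chain on this same oxygen would also leave the reading unchanged stays open. A single concentration also leaves open how these compounds would compare at higher doses, where differences between them might appear.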